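Fluorine on the benzyl ring of a sulfonyl coumarin

The compounds below may be only part of what the source reports. "The series", "measured", "known", "first", "only" and "open" are said of these compounds alone.

Compound 1 `Cc1cc(OCc2nnc(SCc3ccccc3)o2)cc2oc(=O)cc(C)c12` gives only a limit in a functional assay on MCF7 cells (Homo sapiens) for antiproliferative activity, read by MTT assay, with a stated time of 24 h (on this read-out higher numbers stand for weaker inhibition and lower numbers for stronger inhibition), > 100000 nM.
Compound 2 `Cc1cc(OCc2nnc(SCc3cccc(F)c3)o2)cc2oc(=O)cc(C)c12` gives 26000 nM in this assay.
Compound 3 `Cc1cc(OCc2nnc(S(=O)(=O)Cc3ccccc3)o2)cc2oc(=O)cc(C)c12` gives 38600 nM in this assay.

Compound 2 and compound 3 share a change at the benzyl ring: fluoro in place of hydrogen on an aromatic carbon. That change made an at least 3.8-fold lower number from compound 1 to compound 2 (0.58 log units; beyond the scatter), although the starting point is only a limit (the limit of > 100000 nM in this assay, at which 1 of the 3 values shown sits). The cores of compound 1 and compound 3 differ by benzylsulfonyl in place of benzylsulfanyl on an aromatic carbon, a step of an at least 2.5-fold lower number from compound 1 to compound 3 (0.41 log units; beyond the scatter). Compound 3 and compound 2 lie within the scatter of each other, a 1.5-fold higher number from compound 2 to compound 3 (0.17 log units; within the scatter).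

Compound 4 `Cc1cc(OCc2nnc(S(=O)(=O)Cc3cccc(F)c3)o2)cc2oc(=O)cc(C)c12` is the not yet measured partner, differing from compound 3 by fluoro in place of hydrogen on an aromatic carbon, the same change as before. Resting on the step from compound 1 to compound 2 an at least 3.8-fold lower number from compound 1 to compound 2 (0.58 log units; beyond the scatter), compound 4 is expected to show a 1.9-fold lower number from compound 3 to compound 4 (0.29 log units; within the scatter), though a smaller step would not surprise since that earlier step began at a limit. The estimate for compound 4 is 20000 nM, between 8000 nM and 50000 nM.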

Compound 4, half-maximal inhibitory concentration: 70400 nM
For compound 4 the middle estimate is 3.5-fold (0.55 log units) below the measured one, outside the stated range (above it).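

On the core of compound 3, fluoro in place of hydrogen on the benzyl ring gives a 1.8-fold higher number from compound 3 to compound 4 (0.26 log units; within the scatter) in this assay, so no real effect of the change can be claimed on this core. Set beside the earlier pair, the change does not carry over from one core to the other: the same change on two cores in this assay, an at least 3.8-fold lower number (0.58 log units; beyond the scatter) from compound 1 to compound 2 and a 1.8-fold higher number (0.26 log units; within the scatter) from compound 3 to compound 4, at least 7.0-fold (0.84 log units) apart, beyond the scatter of two such steps. On these data alone, the true size of the earlier step stays unknown, and two pairs give no rule for the series, since compound 1 offers only a limit and not a number: the limit of > 100000 nM in this assay, at which 1 of the 4 values shown sits.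

As far as these compounds go, it remains open whether a chloro or methoxy group on the benzyl ring would behave differently on the two cores. An amine there is equally untested by the compounds shown.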